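The compounds below may be only part of what the source reports. "The series", "measured", "known", "first", "only" and "open" are said of these compounds alone.

Within the data shown here, in an assay on membranes from HeLa cells for displacement of a labelled ligand from adenosine receptor A3 (Homo sapiens), read by scintillation counting, with a stated time of 180 min, tested at 1 uM (on this read-out lower numbers stand for less inhibition and higher numbers for more inhibition at the one concentration tested (going by the name of the read-out)), compound 2 `CC1=C(C(=O)OC(C)(C)C)C(c2ccsc2)NC(=O)N1` gives 1%, the lowest of the three numbers measured so far. Compound 1 `CC1=C(C(=O)OC(C)(C)C)C(c2cccs2)NC(=O)N1` gives 7%; the step is a number 6 percentage points lower from compound 1 to compound 2 (within the scatter). Compound 3 `CC1=C(C(=O)OC(C)(C)C)C(c2ccsc2)NC(=O)N1C` gives 14%; the step is a number 13 percentage points higher from compound 2 to compound 3 (beyond the scatter), the only one beyond the scatter. Compound 4 `CC1=C(C(=O)CC(C)C)C(c2ccsc2)NC(=O)N1` is not yet measured and differs from compound 2 by isobutyl in place of tert-butoxy on a carbonyl carbon. Among the measured compounds shown here, neither measured step bears on the carbonyl carbon: one changes the group on a saturated ring carbon, the other an amide-type nitrogen in a ring, so no direct precedent exists for this change. Absent such precedent, the expected step is a number 2 percentage points higher from compound 2 to compound 4 (within the scatter), none beyond the scatter. Compound 4 is therefore estimated at 3%, with a range from -6% to 14%.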

Compound 4, a percentage reported as inhibition, at one concentration (the size of the read-out at that concentration, not a potency): 14%
Estimate against measurement, compound 4: 11 percentage points below; the range from low to high includes it.
By their numbers in this assay, from the lowest: compounds 2, 1, 3 and 4 (each within the scatter of the next, the first and the last beyond it).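

In this assay, among these compounds, isobutyl in place of tert-butoxy on a carbonyl carbon gives a number 13 percentage points higher from compound 2 to compound 4 (beyond the scatter), so the read-out responds to a change at this place, which the earlier steps did not touch. Isobutyl counts no hydrogen-bond acceptor where tert-butoxy counts one, and it has one heavy atom fewer, but this single pair cannot separate these differences. Nothing on hand accounts for the step.

Open, from the compounds shown here alone, is how a longer chain, an amine or a carboxylic acid on this carbonyl carbon would read. Also open, going by these compounds, is whether isobutyl combined with methyl on the ring nitrogen would raise the number further.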